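Swapping Methoxy for Nitrile on an Aminopyridine

The compounds below may be only part of what the source reports. "The series", "measured", "known", "first", "only" and "open" are said of these compounds alone.

Of the compounds shown here, three built on one shared core have been measured in an ADME assay on microsomes from liver (Homo sapiens) for metabolic stability, read by LC-MS, with a stated time of 30 min, tested at 0.1 uM; a higher number here means that more of the compound is left, a lower number that less of the compound is left. Compound 1 `FC(F)(F)Oc1ccc(-c2nc3cnc(Nc4ccccn4)cc3[nH]2)cc1` gives 60% in this assay. Compound 3 `Fc1ccc(-c2nc3cnc(Nc4ccccn4)cc3[nH]2)cc1F` gives 91%. Compound 2 `COc1ccnc(Nc2cc3[nH]c(-c4cccc(C(F)(F)F)c4)nc3cn2)c1` gives 80%, the second highest of the three numbers: compound 3 lies higher by a margin beyond the scatter, and compound 1 lies lower by a larger margin, also beyond the scatter. Compound 4 `N#Cc1ccc(Nc2cc3[nH]c(-c4cccc(C(F)(F)F)c4)nc3cn2)nc1` has not yet been measured; it differs from compound 2 by 5-cyanopyridin-2-yl in place of 4-methoxypyridin-2-yl on a nitrogen on an aromatic ring. For the measured compounds named here, no pair of measured compounds differs in one place only, so nothing measured shows what such a change does. The step is expected to be small, at a number 2 percentage points higher from compound 2 to compound 4 (within the scatter), within the scatter. Compound 4 is expected to give 82%, with a range from 65% to 95%.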

Compound 4, percent of the compound remaining: 39%
The estimate for compound 4 lay 43 percentage points above the measured number; measured number below the stated range.
By their numbers in this assay, from the lowest: compound 4; then compound 1; then compound 2; then compound 3.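

For the compounds shown here, this is the first comparison in the set that changes only one place, and it shows that the group on the nitrogen on an aromatic ring strongly affects the result in this assay: replacing 4-methoxypyridin-2-yl with 5-cyanopyridin-2-yl gives a number 41 percentage points lower from compound 2 to compound 4 (beyond the scatter). Both groups have the same heavy-atom count, so that count does not account for the difference. No measurement here explains the drop.

As far as these compounds go, the swap removes the methoxy and adds the nitrile at once, so the effect of each alone remains open. From the compounds shown here alone, it is also open how an amide or a morpholine would fare on that pyridine.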